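A few compounds are considered here, and "the series" means these few. Any claim that something is new, unique, unknown or untested is made for them only; others in the source may bear on it.

Working notes on the series, read in a functional assay on MGC-803 cells (Homo sapiens) for antiproliferative activity, read by MTT assay, with a stated time of 48 h; a higher number here means a weaker inhibitor, a lower number a stronger inhibitor. Compound 1 `COc1ccc(CN(C(=O)Cn2cc(COc3ccc4ccc(=O)oc4c3)nn2)c2cc(OC)c(OC)c(OC)c2)cc1` gives 180 nM, compound 2 `COc1ccc(CN(C(=O)Cn2cc(CSC3=NCCS3)nn2)c2cc(OC)c(OC)c(OC)c2)cc1` gives 1610 nM, and compound 3 `COc1ccc(CN(C(=O)Cn2cc(CSc3nncs3)nn2)c2cc(OC)c(OC)c(OC)c2)cc1` gives 5000 nM, the highest number of the three and so the weakest inhibitor here.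

Compound 4 `COc1ccc(CN(C(=O)Cn2cc(Cn3ccc4ccccc43)nn2)c2cc(OC)c(OC)c(OC)c2)cc1` differs from compound 3 as follows: 1H-indol-1-yl in place of (1,3,4-thiadiazol-2-yl)sulfanyl on a saturated chain carbon bound to an aromatic carbon. In words, 1H-indol-1-yl stands in place of (1,3,4-thiadiazol-2-yl)sulfanyl on a saturated chain carbon bound to an aromatic carbon.

The closest guide is a 28-fold higher number from compound 1 to compound 3 (1.44 log units; beyond the scatter), a large step that loses a group holding a six-membered aromatic ring of carbon only. The entering 1H-indol-1-yl also holds such a ring. an 8.9-fold higher number from compound 1 to compound 2 (0.95 log units; beyond the scatter) is a modest step of the same kind, and a 3.1-fold higher number from compound 2 to compound 3 (0.49 log units; beyond the scatter) is also modest. Only compound 1 carries such a ring among the measured compounds, so this evidence is thin.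

In this assay a modest to large move toward a lower number is therefore expected. The expected step is a 6.3-fold lower number from compound 3 to compound 4 (0.80 log units; beyond the scatter). For compound 4 the estimate is 800 nM, with an expected range of 180 nM to 3500 nM.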

Compound 4, half-maximal inhibitory concentration: 42600 nM
For compound 4 the middle estimate is 53-fold (1.73 log units) below the measured one; the whole stated range lies below it.
By their numbers in this assay, from the lowest: compound 1; then compound 2; then compound 3; then compound 4.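

In this assay, a carbon-only six-membered aromatic ring in the group on this saturated chain carbon does not by itself give a low number: 1H-indol-1-yl holds such a ring, yet the change from the group of compound 1 gives a 240-fold higher number from compound 1 to compound 4 (2.37 log units; beyond the scatter). Within the data shown here, replacing (1,3,4-thiadiazol-2-yl)sulfanyl with 1H-indol-1-yl gives an 8.5-fold higher number from compound 3 to compound 4 (0.93 log units; beyond the scatter), and the change from the group of compound 2 gives a 26-fold higher number from compound 2 to compound 4 (1.42 log units; beyond the scatter), so compound 4 is the weakest inhibitor of the four and the only one whose group here holds neither oxygen nor sulfur. No data given here account for this result.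

On these data alone, whether the rise follows the loss of those atoms or the indole ring itself remains open. A phenoxy or phenylsulfanyl group on the same saturated chain carbon would help separate the two readings.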